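A few compounds are considered here, and "the series" means these few. Any claim that something is new, unique, unknown or untested is made for them only; others in the source may bear on it.

Measured compounds:

Compound 1, `O=C1O[C@@H](Cn2ccnn2)CN1c1ccc(-n2cc(-c3ccccn3)cn2)c(F)c1`, gives 247000 nM in a physicochemical assay for solubility, read by HPLC, with a stated time of 24 h; a higher number here means a more soluble compound, a lower number a less soluble compound.
Compound 2, `O=CNC[C@H]1CN(c2ccc(-n3cc(-c4ccccn4)cn3)c(F)c2)C(=O)O1`, gives 217000 nM in this assay.
Compound 3, `CN(C)S(=O)(=O)NC[C@H]1CN(c2ccc(-n3cc(-c4ccccn4)cn3)c(F)c2)C(=O)O1`, gives 472000 nM in this assay.

Compound 3 holds the highest of the three numbers. Its nearest neighbour is compound 1, a step of a 1.9-fold higher number from compound 1 to compound 3 (0.28 log units; within the scatter) that lies within the scatter; its furthest is compound 2, a step of a 2.2-fold higher number from compound 2 to compound 3 (0.34 log units; beyond the scatter) that goes beyond it.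

Compound 4, `CCNC(=O)NC[C@H]1CN(c2ccc(-n3cc(-c4ccccn4)cn3)c(F)c2)C(=O)O1`, differs from compound 3 in one place: ethylcarbamoyl in place of dimethylsulfamoyl on an amine nitrogen. For the measured compounds named here, the measured step that bears most directly on this change is the one from compound 2 to compound 3, a 2.2-fold higher number from compound 2 to compound 3 (0.34 log units; beyond the scatter), where dimethylsulfamoyl took the place of formyl on the same amine nitrogen. The other steps at this part of the molecule, a 1.1-fold lower number from compound 1 to compound 2 (0.06 log units; within the scatter) and a 1.9-fold higher number from compound 1 to compound 3 (0.28 log units; within the scatter), stayed within the scatter. Three substituents on this amine nitrogen therefore span a narrow band of numbers, and ethylcarbamoyl is expected to fall inside it, most likely somewhat below compound 3, a step of a 1.6-fold lower number from compound 3 to compound 4 (0.20 log units; within the scatter).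

Compound 4 is estimated at 300000 nM, with a range from 150000 nM to 600000 nM.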

Compound 4, solubility: 222000 nM
The estimate for compound 4 lay 1.4-fold (0.13 log units) above the measured number, within the range that was stated.
By their numbers in this assay, from the lowest: compounds 2, 4, 1 and 3 (each within the scatter of the next, the first and the last beyond it).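

In this assay, ethylcarbamoyl on the amine nitrogen falls in with formyl and not with dimethylsulfamoyl: the comparison with the formyl compound reads a 1.0-fold higher number from compound 2 to compound 4 (0.01 log units; within the scatter), whereas the exchange of dimethylsulfamoyl for ethylcarbamoyl reads a 2.1-fold lower number from compound 3 to compound 4 (0.33 log units; beyond the scatter). For the compounds shown here, the single modest step that had set dimethylsulfamoyl apart from formyl now has a second counterpart on the same amine nitrogen, although compound 1 goes against any clean separation, lying within the scatter of compound 3 and also of compound 4, as a 1.1-fold lower number from compound 1 to compound 4 (0.05 log units; within the scatter) shows. Nothing among the data shown offers an explanation for these differences.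

The compounds shown leave open whether the separation of compound 3 from compound 2 and compound 4 belongs to the sulfonyl unit as such or to its dimethylamino part, a question that a methanesulfonyl group or an unsubstituted sulfamoyl group on the same amine nitrogen would address. They also leave open what a group carrying a free amine or a carboxylic acid at this place would give in this assay.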